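The source may report more compounds than this note shows. Statements on the series, on what has been measured and on what is new or still open speak of the compounds shown alone.

In a functional assay on SW480 cells (Homo sapiens) for antiproliferative activity, read by MTT assay, with a stated time of 48 h (on this read-out higher numbers stand for weaker inhibition and lower numbers for stronger inhibition), compound 1 `CCCCCCCCCC(CCO)n1cnc2c(Cl)ncnc21` gives 1150 nM, while compound 2 `CCCCCCCCC[C@H](CCOS(C)(=O)=O)n1cnc2c(Cl)ncnc21` gives 9720 nM. Compound 2 therefore holds the higher of the two numbers, which means the weaker inhibition, and the gap between the two lies beyond the usual scatter. Compound 3 `CCCCCCCCCC(CCOS(C)(=O)=O)n1cnc2c(Cl)ncnc21` differs from compound 2 only in how one feature is drawn: the two compounds have the same atoms and bonds; at least one stereo element is drawn with a configuration in one of them and without one in the other: 1 of 1 stereo elements differ; a stereocentre at a saturated chain carbon is drawn R in compound 2 and without a configuration in compound 3. A stereocentre at a saturated chain carbon is drawn R in compound 2 and without a configuration in compound 3. The two compounds have the same atoms and bonds. Within the data shown here, no measured pair yet shows what such a difference does, so no step beyond the scatter is expected in this assay, in either direction. Expressed as a step, the estimate is a 1.1-fold lower number from compound 2 to compound 3 (0.03 log units; within the scatter). For compound 3 the estimated value is 9000 nM, with an expected range of 4000 nM to 20000 nM.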

Compound 3, half-maximal inhibitory concentration: 5390 nM
Estimate against measurement, compound 3: 1.7-fold (0.22 log units) above, within the range that was stated.
By their numbers in this assay, from the lowest: compound 1; then compounds 3 and 2 (each within the scatter of the next).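

In this assay, methylsulfonyl in place of hydrogen on an oxygen on a saturated carbon can now be read as a single change, and it weakens inhibition, with a 4.7-fold higher number from compound 1 to compound 3 (0.67 log units; beyond the scatter). Whether the stereocentre at the saturated chain carbon is drawn R or left without a configuration makes no difference beyond the scatter, with a 1.8-fold lower number from compound 2 to compound 3 (0.26 log units; within the scatter). This pair therefore gives no sign of a preference at this centre, and the only thing that separates its two members is this: the fact that one of compounds 2 and 3 is drawn with a defined configuration and the other without, at the place where they differ

From the compounds shown here alone, a drawing without a configuration does not tell which forms the sample holds, and the configuration opposite to R remains open. Also open, going by these compounds, is how an acetyl group or an amine in place of methylsulfonyl, or a longer chain, would read here.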